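The compounds below may be only part of what the source reports. "The series", "measured", "known", "first", "only" and "open" are said of these compounds alone.

Compound 1 `COc1cc(/C=C/C(=O)C2=C(/C=C/c3ccc(O)c(OC)c3)NC(=O)NC2c2ccccc2)ccc1O`: 26.4%
Compound 2 `COc1cc(/C=C/C(=O)C2=C(/C=C/c3ccc(O)c(OC)c3)NC(=O)NC2c2ccc(C)cc2)ccc1O`: 29.9%

In a functional assay, with a stated time of 20 min, tested at 10 uM (on this read-out lower numbers stand for a weaker effect and higher numbers for a stronger effect at the one concentration tested), compound 2 gives 29.9%, and in the same read-out compound 1 gives 26.4%. Of the two numbers shown, compound 2 has the numerically higher one, but the step of a number 3.5 percentage points higher from compound 1 to compound 2 (within the scatter) lies within the scatter, so the two compounds are not told apart. Compound 3 `COc1cc(/C=C/C(=O)C2=C(/C=C/c3ccc(O)c(OC)c3)NC(=O)NC2c2ccccc2O)ccc1O` differs from compound 2 by 2-hydroxyphenyl in place of 4-methylphenyl on a saturated ring carbon. Within the data shown here, the only measured step that bears on this change is the one from compound 1 to compound 2, which altered the group on the same saturated ring carbon and was within the scatter. Among the measured compounds shown here, no measured step involves a 2-hydroxyphenyl group, so nothing shows how such a group moves the read-out. Compound 3 is therefore expected to give about 28%, within 14% to 44%, meaning an expected step of a number 1.9 percentage points lower from compound 2 to compound 3 (within the scatter) that stays within the scatter.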

Compound 3, a percentage reported as activity, at one concentration (the size of the read-out at that concentration, not a potency): 73.6%
Estimate against measurement, compound 3: 45.6 percentage points below; the whole stated range lies below it.
By their numbers in this assay, from the lowest: compounds 1 and 2 (each within the scatter of the next); then compound 3.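

The result shows that in this assay the group on this saturated ring carbon can matter a great deal, which the earlier change there, within the scatter, did not reveal. The exchange of 4-methylphenyl for 2-hydroxyphenyl gives a number 43.7 percentage points higher from compound 2 to compound 3 (beyond the scatter) and the addition of a single hydroxy group gives a number 47.2 percentage points higher from compound 1 to compound 3 (beyond the scatter) with the rest of the structure unchanged, so the rise in this series is tied to adding that hydroxy group. No measurement shown here explains the rise.

It remains open whether the hydroxy group is itself required, since the compounds shown do not tell what a methoxy group, an amine or a carboxylic acid would give in its place. They also leave open whether a hydroxy group elsewhere on this aromatic ring would give a similar number.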